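Ring-for-chain swap on a nitrogen substituent

A few compounds are considered here, and "the series" means these few. Any claim that something is new, unique, unknown or untested is made for them only; others in the source may bear on it.

Measured so far:
compound 1 `CCN1CCN(c2nc(C)nc3c2nc(-c2ccccc2Cl)n3C)CC1` gives 30%
compound 2 `CCN1CCN(c2nc(C)nc3c2nc(-c2ccccc2Cl)n3CCOC)CC1` gives 53%

In an ADME assay (liver) for metabolic stability, with Liver microsome (Rattus norvegicus) as the target, read by LC-MS, using microsomes, with a stated time of 30 min, tested at 4 uM (a higher number here means that more of the compound is left, a lower number that less of the compound is left), compound 2 stands highest of the two numbers, with compound 1 the nearest and lower, the step of a number 23 percentage points higher from compound 1 to compound 2 (beyond the scatter) lying beyond the scatter. Compound 3 `CCN1CCN(c2nc(C)nc3c2nc(-c2ccccc2Cl)n3CC2CCOCC2)CC1` has not been measured. Its difference from compound 2 is oxan-4-yl in place of methoxymethyl on a saturated chain carbon bound to an aromatic nitrogen. Within the data shown here, the one measured step that bears on this position is a number 23 percentage points higher from compound 1 to compound 2 (beyond the scatter), which is modest and upward, but it compares hydrogen with methoxymethyl, not methoxymethyl with oxan-4-yl, so no measured step tells how the ring-bearing group will behave. The expectation is therefore for compound 3 to remain near compound 2, with a step of a number 3 percentage points lower from compound 2 to compound 3 (within the scatter) that is not expected to exceed the scatter. Compound 3 is estimated at 50%, within a range from 30% to 70%.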

Compound 3, percent of the compound remaining: 80%
For compound 3 the middle estimate is 30 percentage points below the measured one; measured number outside the range, above it.
By their numbers in this assay, from the lowest: compound 1; then compound 2; then compound 3.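

In this assay the place on a saturated chain carbon bound to an aromatic nitrogen responds to the shape of the group as well as to its presence: oxan-4-yl in place of methoxymethyl gives a number 27 percentage points higher from compound 2 to compound 3 (beyond the scatter) and so adds to what the open chain had already gained. Set against compound 1, the same group gives a number 50 percentage points higher from compound 1 to compound 3 (beyond the scatter) and this is the only large step among the three compounds. No evidence is available on what lies behind these rises.

The compounds shown leave open whether the ring itself or its oxygen matters, which a cyclohexyl group in place of oxan-4-yl would test. They also leave open how a smaller ring such as oxetane, or a ring amine such as piperidine, would behave at this place.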